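The source may report more compounds than this note shows. Statements on the series, on what has been measured and on what is new or still open speak of the compounds shown alone.

The study concerns a small set of aryl sulfonate esters tested in a functional assay on MCF7 cells (Homo sapiens) for antiproliferative activity, read by sulforhodamine B assay, with a stated time of 48 h; on this read-out lower numbers stand for stronger inhibition and higher numbers for weaker inhibition. Compound 1 `Cc1ccccc1OS(=O)(=O)c1ccc(N2CCN(C)C2=O)cc1` gives 5600 nM there. Compound 2 `COc1ccccc1OS(=O)(=O)c1ccc(N2CCN(C)C2=O)cc1` differs from it by methoxy in place of methyl on an aromatic carbon, and in this assay compound 2 gives 26000 nM, a shift of a 4.6-fold higher number from compound 1 to compound 2 (0.67 log units; beyond the scatter). Compound 3 `CCCN1CCN(c2ccc(S(=O)(=O)Oc3ccc(C)cc3)cc2)C1=O` rests on a different core, and the difference between the two cores is not broken down here. In this assay compound 3 gives 64000 nM, the highest of the three numbers.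

Compound 4 `CCCN1CCN(c2ccc(S(=O)(=O)Oc3ccc(OC)cc3)cc2)C1=O` has not yet been measured. It differs from compound 3 by methoxy in place of methyl on an aromatic carbon. Among the measured compounds shown here, this is the same kind of change as the one from compound 1 to compound 2, but not the same: in compound 1 the group that leaves sits ortho to a large group, whereas in compound 3 it sits para to a large group. For the measured compounds named here, only one instance of this change has been measured, so the expectation rests on that single step. On the strength of a 4.6-fold higher number from compound 1 to compound 2 (0.67 log units; beyond the scatter), the expected step is a 2.3-fold higher number from compound 3 to compound 4 (0.37 log units; beyond the scatter). Going by the values given here, because compound 3 already stands at 64000 nM, compound 4 is expected to give a still higher number than any compound measured so far. Compound 4 is estimated at 150000 nM, with a range from 50000 nM to 400000 nM.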

Compound 4, half-maximal inhibitory concentration: 20000 nM
Beside the measured number, compound 4's estimate is 7.5-fold (0.88 log units) above it; the whole stated range lies above it.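

In this assay, the exchange of methyl for methoxy on an aromatic carbon, para to a large group, gives a 3.2-fold lower number from compound 3 to compound 4 (0.51 log units; beyond the scatter), so here the methoxy compound carries the lower number. Set beside the only earlier instance, the same exchange runs in opposite directions on the two cores, and the gap between the two steps is larger than the scatter allows: the same change on two cores in this assay, a 4.6-fold higher number (0.67 log units; beyond the scatter) from compound 1 to compound 2 and a 3.2-fold lower number (0.51 log units; beyond the scatter) from compound 3 to compound 4, 15-fold (1.17 log units) apart, beyond the scatter of two such steps. This shows that, in this series, the step cannot be carried from one core to another as a fixed shift, or even with a fixed direction; it does not show which difference between the two pairs goes with the reversal, as they differ in more than one place, and two steps give no general rule.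

The compounds shown leave open whether the reversal follows the position of the group on the aromatic ring or the rest of the core, a question that a 4-methylphenoxy and 4-methoxyphenoxy pair on the core of compound 1 would address. They also leave open how an amine or a carboxylic acid in place of the methyl or methoxy would read on either core, and what a longer chain on the ring nitrogen would do.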